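The compounds below may be only part of what the source reports. "The series", "measured", "known", "first", "only" and "open" are said of these compounds alone.

Working notes on the series. Compound 1 `COc1cccc(CNCCCNc2ccnc3cc(Oc4ccc(Cl)cc4)ccc23)c1O`, compound 2 `COc1ccc(F)cc1CNCCCNc1ccnc2cc(Cc3ccc(F)cc3)ccc12` and compound 3 `COc1cccc(CNCCCNc2ccnc3cc(Oc4ccccc4)ccc23)c1O` have been measured in a physicochemical assay for solubility, with a stated time of 18 h, at pH 7.4; a lower number here means a less soluble compound, a higher number a more soluble compound. Compound 1 gives 14500 nM, compound 2 gives 4200 nM, and compound 3 gives 14500 nM. Compound 3 stands level with compound 1, the two together making up the highest numbers of the three; compound 2 lies furthest from it, with a lower number. For the measured compounds named here, the only step between measured compounds that differ in one place, no change at the digits printed from compound 1 to compound 3 (within the scatter), covers hydrogen in place of chloro on an aromatic carbon and does not touch the exchange at hand.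

Compound 4 `COc1cccc(CNCCCNc2ccnc3cc(Cc4ccc(F)cc4)ccc23)c1O` is next to be measured in this assay. Its difference from compound 3: 4-fluorobenzyl in place of phenoxy on an aromatic carbon. Going by the values given here, no measured step covers this exchange directly. Compound 2 carries the same 4-fluorobenzyl group on the shared core, though with a different group on the amine side, and gives a lower value than compound 3; that is the only indication available, and the gap it shows is taken as the outer bound. On that basis compound 4 is expected to show a lower number in this assay, the step of a 2.1-fold lower number from compound 3 to compound 4 (0.32 log units; beyond the scatter) being expected to lie beyond the scatter yet to fall short of that outer bound. The estimate for compound 4 in this assay is 7000 nM, with a range from 2500 nM to 20000 nM.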

Compound 4, solubility: 4200 nM
Beside the measured number, compound 4's estimate is 1.7-fold (0.22 log units) above it, within the range that was stated.
By their numbers in this assay, from the lowest: compounds 2 and 4 (each within the scatter of the next); then compounds 1 and 3 (each within the scatter of the next).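

In this assay, for the compounds shown here, the exchange at this position can now be read directly: with 4-fluorobenzyl in place of phenoxy there is a 3.5-fold lower number from compound 3 to compound 4 (0.54 log units; beyond the scatter), and with 4-fluorobenzyl in place of 4-chlorophenoxy there is a 3.5-fold lower number from compound 1 to compound 4 (0.54 log units; beyond the scatter), whereas the only earlier step, the loss of chloro from the phenoxy ring, left the number unchanged. With 4-fluorobenzyl held fixed, the exchange of 2-hydroxy-3-methoxyphenyl for 5-fluoro-2-methoxyphenyl on the amine side gives no change at the digits printed from compound 2 to compound 4 (within the scatter), so in this pair the amine-side group does not move the number beyond the scatter and the step seen so far belongs to the aromatic position. Nothing at hand offers an explanation for the size of that step.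

From the compounds shown here alone, the exchange changes both the linking atom and the ring substituent, so it remains open which of the two carries the step; a plain benzyl group or a 4-chlorobenzyl group at this position would separate them. Going by these compounds, it also remains open whether the amine-side exchange stays within the scatter when phenoxy occupies the position, as a pairing of 5-fluoro-2-methoxyphenyl with phenoxy would show.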